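The source may report more compounds than this note shows. Statements on the series, on what has been measured and on what is new or still open speak of the compounds shown alone.

Measured so far:
- compound 1 `COc1ccc([C@@H]2CC(=O)c3cc(CC=C(C)C)c(OC)cc3O2)cc1`: 45%
- compound 2 `CCCCOc1ccc([C@@H]2CC(=O)c3cc(CC=C(C)C)c(OC)cc3O2)cc1`: 37%
- compound 3 `COc1ccc([C@@H]2C/C(=N/OCc3cn(-c4cccc(CO)c4)nn3)c3cc(CC=C(C)C)c(OC)cc3O2)cc1`: 43%

These values come from a functional assay on A549 cells (Homo sapiens) for inhibition, read by sulforhodamine B assay, with a stated time of 48 h, tested at 50 uM; a higher number here means more inhibition of growth at the concentration tested, a lower number less inhibition of growth. Compound 2 sits within the scatter of both other compounds, so the three cannot be ranked. Compound 4 `COc1cc2c(cc1CC=C(C)C)C(=O)C[C@@H](c1ccc(Oc3ccc(Br)cc3)cc1)O2` has 4-bromophenyl in place of butyl on an oxygen on an aromatic ring, (4-bromophenyl in place of butyl on an oxygen on an aromatic ring). For the measured compounds named here, the one measured step at that oxygen, a number 8 percentage points lower from compound 1 to compound 2 (within the scatter), stays within the scatter. Going by the values given here, no measured compound carries a ring there, so this evidence is thin, and no shift beyond the scatter is expected. The expected change is no change at the digits printed from compound 2 to compound 4 (within the scatter). For compound 4 the estimated value is 37%, with an expected range from 20% to 54%.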

Compound 4, percent growth inhibition at one concentration: 72%
The estimate for compound 4 lay 35 percentage points below the measured number; measured number outside the range, above it.
By their numbers in this assay, from the lowest: compounds 2, 3 and 1 (each within the scatter of the next); then compound 4.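

At the oxygen on an aromatic ring, replacing the alkyl group with 4-bromophenyl gives a number 35 percentage points higher from compound 2 to compound 4 (beyond the scatter) and, starting from the methyl group, a number 27 percentage points higher from compound 1 to compound 4 (beyond the scatter) (both in this assay). Butyl and methyl there had stayed within the scatter of each other, so this position does respond to a change of group, and compound 4 alone carries a ring there. No evidence on hand explains the rise. The compounds shown leave open whether it comes from the bromine or from the ring itself, which a plain phenyl or a 4-chlorophenyl at that oxygen would help separate.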